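Aryl swap on the carbon bound to the amide nitrogen

A few compounds are considered here, and "the series" means these few. Any claim that something is new, unique, unknown or untested is made for them only; others in the source may bear on it.

Two members of the shared core have so far been tested in an assay on isolated protein with Bile acid receptor (Homo sapiens) as the target; on this read-out higher numbers stand for an effect only at larger amounts of compound and lower numbers for an effect already at smaller amounts. Compound 1 `COC(=O)/C=C/c1cccc(N(Cc2ccc(-c3ccc(OC)cc3)cc2)C(=O)C2CCCCC2)c1` gives 89 nM in this assay. Compound 2 `COC(=O)/C=C/c1cccc(N(Cc2cccc(Br)c2)C(=O)C2CCCCC2)c1` is reported only as > 1000 nM, which is a limit of this assay and not a number. Going by the values given here, the one piece of evidence on the pair is this: the limit of > 1000 nM in this assay, at which 1 of the 2 values shown sits. Among the compounds with values here, compound 2 thus stands at the weaker end of what has been seen so far, with compound 1 the only numbered point of comparison and no step between the two computed.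

Compound 3 `COC(=O)/C=C/c1cccc(N(Cc2ccc(C(C)(C)C)cc2)C(=O)C2CCCCC2)c1` has not yet been measured. It differs from compound 2 in one place: 4-(tert-butyl)phenyl in place of 3-bromophenyl on a saturated chain carbon bound to an amide-type nitrogen. Within the data shown here, no measured step covers this exchange, so the expectation rests on the two values above. A move from compound 2 in the direction of lower numbers is expected for an at least 3.3-fold lower number from compound 2 to compound 3 (0.52 log units; beyond the scatter), beyond the usual scatter, because compound 1 at 89 nM shows that a 4-substituted phenyl on this carbon is compatible with a numbered result. Compound 3 is therefore estimated at 300 nM, with a range from 70 nM to 2000 nM.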

Compound 3, half-maximal effective concentration: > 1000 nM
Compound 3 gave a limit, no number (the forecaster's own chance of this, stated with the estimate: 25%); at least 3.3-fold (0.52 log units) between middle value and limit.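

In this assay compound 3 is reported only as > 1000 nM, which is a limit and not a number, and the step that links it to compound 2 cannot be read. The readable information lies in tert-butyl in place of 4-methoxyphenyl on an aromatic carbon, which gives an at least 11-fold higher number from compound 1 to compound 3 (1.05 log units; beyond the scatter), so a large group on that aromatic carbon does not by itself keep a numbered result, and within this pair the number goes with the 4-methoxyphenyl. Compound 1 remains the only member of the series with a numbered value, while the limit now takes in most of the set: the limit of > 1000 nM in this assay, at which 2 of the 3 values shown sit.

On these data alone, it remains open whether the number of compound 1 depends on the second aromatic ring as such or on its methoxy group, a question that a plain phenyl or a 4-hydroxyphenyl on the same aromatic carbon would address. Also open, as far as these compounds go, is how an amine or a carboxylic acid on that outer ring would read out in this assay, and how far compound 2 and compound 3 actually lie from each other.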